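The source may hold more compounds than are shown below. What is called first, only, known or untested is meant among the compounds shown, and "the series" means these compounds.

Measured compounds:
compound 1, `CC(C(=O)NCc1ccc(C(C)(C)C)cc1)c1ccc(NS(C)(=O)=O)c(Cl)c1`, 29.5 nM
compound 2, `CC(C(=O)NCc1ccc(C(C)(C)C)cc1)c1cc(F)c(NS(C)(=O)=O)c(F)c1`, 7.4 nM

These two compounds were tested in a functional assay on CHO cells for antagonist activity at transient receptor potential cation channel subfamily V member 1 (Rattus norvegicus), read by fluorescence, with a stated time of 1 h; a higher number here means a weaker inhibitor, a lower number a stronger inhibitor. Compound 1 gives 29.5 nM, and compound 2 gives 7.4 nM. Of the two numbers, compound 1 stands at the higher one, so it is the weaker inhibitor of the pair, and the gap to compound 2 is wider than repeated measurements would usually produce. Within the data shown here, compound 2 differs from compound 1 in more than one place, so no single step is drawn between them.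

Compound 3, `Cc1cc(C(C)C(=O)NCc2ccc(C(C)(C)C)cc2)ccc1NS(C)(=O)=O`, has not yet been measured. It keeps the shared core of compound 1 and changes one thing: methyl in place of chloro on an aromatic carbon. Among the measured compounds shown here, nothing measured so far isolates this change, so there is no step to lean on. The expectation is a small move, if any: compound 3 is estimated to lie in the region of compound 1, with a step of a 1.4-fold higher number from compound 1 to compound 3 (0.13 log units; within the scatter) that may well fall within the usual scatter. Compound 3 is expected to give 40 nM, within a range from 12 nM to 130 nM.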

Compound 3, inhibition constant: 18.9 nM
Compound 3: middle estimate off by 2.1-fold (0.33 log units), on the high side, and the stated range covers the measured number.
By their numbers in this assay, from the lowest: compound 2; then compounds 3 and 1 (each within the scatter of the next).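

Replacing chloro with methyl on this aromatic carbon, ortho to a methanesulfonamido group, gives a 1.6-fold lower number from compound 1 to compound 3 (0.19 log units; within the scatter) in this assay, so the two compounds cannot be told apart in this measurement. Among these compounds, this is the first pair here that differs in only one place, and it shows that this position can carry either chloro or methyl without a change that stands clear of the usual variation between repeated measurements; each group counts one heavy atom, with no hydrogen-bond donors or acceptors and no net charge. Nothing available bears on why these two groups give such similar results.

The compounds shown leave open how far this tolerance extends, for instance whether plain hydrogen, a methoxy group, a trifluoromethyl group or an amine on the same carbon would keep the number in this region or move it clearly. They also leave open what the two fluoro groups of compound 2 contribute, as compound 2 differs from compound 1 in more than one place and no single change can be isolated.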